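The source may report more compounds than this note shows. Statements on the series, on what has been measured and on what is new or still open speak of the compounds shown alone.

Among the two compounds measured so far in a functional assay on SW-620 cells (Homo sapiens) for cytotoxicity, read by MTT assay, with stated times of 4 h and 72 h, tested at 2 uM (a lower number here means a stronger inhibitor, a higher number a weaker inhibitor), compound 1 `COc1ccc(/C=C/C(=O)c2ccc(Nc3cc(C)nc4nc(SCc5nc6ccccc6[nH]5)nn34)cc2)cc1F` has the lowest number, at 140 nM. For the measured compounds named here, compound 2 `Cc1cc(Nc2ccc(C(=O)/C=C/c3ccc(Cl)cc3)cc2)n2nc(SCc3nc4ccccc4[nH]3)nc2n1` gives 230 nM in this assay; the only measured step, a 1.6-fold higher number from compound 1 to compound 2 (0.22 log units; within the scatter), swaps the same ring that changes here for another chlorine-bearing ring. Compound 3 `Cc1cc(Nc2ccc(C(=O)/C=C/c3cccc(Cl)c3)cc2)n2nc(SCc3nc4ccccc4[nH]3)nc2n1` carries 3-chlorophenyl in place of 3-fluoro-4-methoxyphenyl on a double-bonded chain carbon bound to a double-bonded chain carbon. Because the step of a 1.6-fold higher number from compound 1 to compound 2 (0.22 log units; within the scatter) lay within the scatter, compound 3 is expected to show a step of a 1.4-fold higher number from compound 1 to compound 3 (0.15 log units; within the scatter), nothing beyond the scatter. Compound 3 is therefore estimated at 200 nM, in the range 100 nM to 400 nM.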

Compound 3, half-maximal inhibitory concentration: 400 nM
For compound 3 the middle estimate is 2.0-fold (0.30 log units) below the measured one; the range from low to high includes it.
By their numbers in this assay, from the lowest: compounds 1, 2 and 3 (each within the scatter of the next, the first and the last beyond it).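

In this assay the ring on the double-bonded chain carbon now shows a step beyond the scatter, a 2.9-fold higher number from compound 1 to compound 3 (0.46 log units; beyond the scatter) when 3-chlorophenyl replaces 3-fluoro-4-methoxyphenyl, so a change at this position can register in the read-out. The step of a 1.7-fold higher number from compound 2 to compound 3 (0.24 log units; within the scatter) stays within the scatter, so 4-chlorophenyl and 3-chlorophenyl cannot be told apart here. Nothing available explains the larger step. The compounds shown leave open how this position would respond to a ring carrying an amine or a carboxylic acid. They also do not separate the fluorine from the methoxy group in 3-fluoro-4-methoxyphenyl.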